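Methoxy to Hydroxy on a Second Core

A few compounds are considered here, and "the series" means these few. Any claim that something is new, unique, unknown or untested is made for them only; others in the source may bear on it.

Measured so far in a functional assay on KM12 cells (Homo sapiens) for inhibition, read by sulforhodamine B assay, with a stated time of 48 h; on this read-out lower numbers stand for higher toxicity in this test and higher numbers for lower toxicity in this test:
- compound 1, `COc1cc(-c2nn(-c3cccc(NC(=O)Nc4cc(C(F)(F)F)cc(C(F)(F)F)c4)c3)cc2-c2ccncc2)ccc1Cl`, gives 3390 nM
- compound 2, `O=C(Nc1cccc(-n2cc(-c3ccncc3)c(-c3ccc(Cl)c(O)c3)n2)c1)Nc1cc(C(F)(F)F)cc(C(F)(F)F)c1`, gives 4060 nM
- compound 3, `COc1cc(-c2nn(-c3cccc(NC(=O)Nc4ccc(Cl)c(C(F)(F)F)c4)c3)cc2-c2ccncc2)ccc1Cl`, gives 14900 nM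

Compounds 1 and 2 share one core and differ in a single spot: hydrogen in place of methyl on an oxygen on an aromatic ring. That change produced a 1.2-fold higher number from compound 1 to compound 2 (0.08 log units; within the scatter), so the two numbers cannot be told apart in this test. Compound 3 stands on a different footing: in this assay it shows the highest number of the three, beyond the scatter against both compound 1 and compound 2. How the core of compound 3 differs from the core of compound 1 is not broken down here.

Compound 4, `O=C(Nc1cccc(-n2cc(-c3ccncc3)c(-c3ccc(Cl)c(O)c3)n2)c1)Nc1ccc(Cl)c(C(F)(F)F)c1`, has not yet been measured. It is built from compound 3 by the same change already seen: hydrogen in place of methyl on an oxygen on an aromatic ring. The place of the change is the same word for word in both pairs, so this is the same change carried onto a second core. Among the measured compounds shown here, the only measured example of it, from compound 1 to compound 2, stayed within the scatter, and the expectation for compound 4 rests on that example alone. A step of about a 1.1-fold higher number from compound 3 to compound 4 (0.03 log units; within the scatter) is expected because the earlier pair gave a 1.2-fold higher number from compound 1 to compound 2 (0.08 log units; within the scatter). Starting from compound 3, which gives 14900 nM, compound 4 is therefore expected to land near 16000 nM, most likely between 7000 nM and 36000 nM.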

Compound 4, concentration lethal to 50% of the cells: 17400 nM
Compound 4: the middle estimate sits 1.1-fold (0.04 log units) below what was measured, within the range that was stated.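

On the second core, the change from methoxy to hydroxy, which turns 4-chloro-3-methoxyphenyl into 4-chloro-3-hydroxyphenyl, gave in this assay a 1.2-fold higher number from compound 3 to compound 4 (0.07 log units; within the scatter). Set side by side, the steps on the two cores agree: the same change on two cores in this assay, a 1.2-fold higher number (0.08 log units; within the scatter) from compound 1 to compound 2 and a 1.2-fold higher number (0.07 log units; within the scatter) from compound 3 to compound 4, 1.0-fold (0.01 log units) apart, within the scatter of two such steps So in these two pairs the change carried from one core to the other as a step too small to read, and this test does not tell methoxy from hydroxy on either core; what this does not show is that the same would hold on any further core or in any other test, since two pairs are too few to make a rule, and two steps that both lie within the scatter say little beyond the fact that neither could be told from no step at all.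

The compounds shown carry only methoxy or hydroxy at this spot, so it stays open how this test would respond to an ethoxy group or a longer chain on that oxygen, or to an amine or a carboxylic acid in place of the hydroxy. Also open, from the compounds shown here alone, is whether the result would hold on a third core, for instance one carrying a nitrile in place of a trifluoromethyl.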